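The source may hold more compounds than are shown below. What is called first, only, known or untested is meant among the compounds shown, and "the series" means these compounds.

The three measured compounds share one core, seen in compound 1 `Cc1ccc(S(=O)(=O)NCc2ccc(CNC(=O)c3ccccc3)cc2)cc1`, compound 2 `O=C(NCc1ccc(CNS(=O)(=O)c2ccccc2)cc1)c1ccccc1Cl` and compound 3 `COc1cccc(C(=O)NCc2ccc(CNS(=O)(=O)c3ccc(C)cc3)cc2)c1`, and differ only in the aromatic ring on the carbonyl carbon. In an assay on MDA-MB-231 cells for binding affinity to C-X-C chemokine receptor type 4 (Homo sapiens), read by immunofluorescence and microscopy, with stated times of 10 min and 30 min (a higher number here means that more compound is needed for the effect, a lower number that less compound is needed), compound 1 gives only a limit, > 1000 nM. Compound 3 puts a methoxy in place of hydrogen on that ring, and in this assay compound 3 gives 10 nM, a step of an at least 100-fold lower number from compound 1 to compound 3 (2.00 log units; beyond the scatter). Because of the limit of > 1000 nM in this assay, at which 1 of the 3 values shown sits, the full size of this step is not known exactly. Compound 2 bears a 2-chlorophenyl on the carbonyl carbon, and in this assay compound 2 gives 10 nM, level with compound 3 at the digits shown. Compound 4 `O=C(NCc1ccc(CNS(=O)(=O)c2ccccc2)cc1)c1ccc(Cl)cc1` has not been measured; it differs from compound 2 in one place: 4-chlorophenyl in place of 2-chlorophenyl on a carbonyl carbon. Among the measured compounds shown here, no measured pair moves a substituent from one position to another on this ring, so the only guidance is that compound 2 and compound 3, each carrying a single substituent there, both return measurable numbers. A modest loss is judged a little more likely than a gain, so compound 4 is expected to give 40 nM in this assay, within 5 nM to 500 nM, an expected step of a 4.0-fold higher number from compound 2 to compound 4 (0.60 log units; beyond the scatter).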

Compound 4, effective concentration (reported as EC, without a stated level of effect): 100 nM
The estimate for compound 4 lay 2.5-fold (0.40 log units) below the measured number; low and high end bracket the measured number.
By their numbers in this assay, from the lowest: compounds 2 and 3 (each within the scatter of the next); then compound 4. At a limit, above all of these: compound 1.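

The step in this assay shows that the place of the chlorine on this ring matters, not only its presence: the two compounds hold the same atoms, joined differently, yet 4-chlorophenyl in place of 2-chlorophenyl on the carbonyl carbon gives a 10-fold higher number from compound 2 to compound 4 (1.00 log units; beyond the scatter). Among the compounds shown here, the only earlier step between compounds that differ in one place, an at least 100-fold lower number from compound 1 to compound 3 (2.00 log units; beyond the scatter), showed that adding a methoxy to this ring can change the number a great deal, but it could not show whether moving a group around the ring would do the same. The new pair adds that point, and it also shows that 4-chlorophenyl still returns a number rather than a limit, though nothing measured here accounts for the step.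

From the compounds shown here alone, whether a bromine or a methyl would show the same gap between these two places on the ring stays open, and so does the outcome for the same move with a methoxy. What an amine or a carboxylic acid on this ring would give is also unknown, as is whether the step between compound 2 and compound 4 would keep its size with a different group on the sulfonyl side of the shared core.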